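The source may hold more compounds than are shown below. What is called first, only, known or untested is meant among the compounds shown, and "the series" means these compounds.

In a functional assay on Hep 3B2 cells (Homo sapiens) for inhibition, read by MTT assay, with a stated time of 72 h (a lower number here means a stronger inhibitor, a higher number a weaker inhibitor), compound 1 (`CNC(=O)CCCCCCCn1nc(-c2cnc3[nH]ccc3c2)c2c(N)ncnc21`) gives 16300 nM and compound 2 (`Nc1ncnc2c1c(-c1cnc3[nH]ccc3c1)nn2CCCCCCCCC(=O)NO`) gives 8390 nM as its value. For the measured compounds named here, these are the only two measurements and they lie within the scatter of each other, so compound 2 cannot be ranked against compound 1.

Compound 3 (`Nc1ncnc2c1c(-c1cnc3[nH]ccc3c1)nn2CCCCCC(=O)NO`) keeps the hydroxycarbamoyl group of compound 2 on a shorter chain, the full change being hydroxycarbamoyl in place of 3-(hydroxycarbamoyl)propyl on a saturated chain carbon, five bonds along the chain from an aromatic nitrogen as counted. In words, hydroxycarbamoyl stands in place of 3-(hydroxycarbamoyl)propyl on a saturated chain carbon, five bonds along the chain from an aromatic nitrogen.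

Going by the values given here, the only measured step is a 1.9-fold lower number from compound 1 to compound 2 (0.29 log units; within the scatter) and it puts (hydroxycarbamoyl)methyl in place of methylcarbamoyl, a different exchange from this one. Among the compounds with values here, no measured pair shows the removal of a 3-(hydroxycarbamoyl)propyl piece, so the data set no size or direction for it. Compound 2 at 8390 nM is therefore the only anchor. The expected size is a 1.2-fold higher number from compound 2 to compound 3 (0.08 log units; within the scatter) and so no shift beyond the scatter is expected in this assay although the uncertainty remains wide. For compound 3 the estimate is 10000 nM (expected range 3000 nM to 30000 nM).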

Compound 3, half-maximal inhibitory concentration: > 50000 nM
Compound 3: a limit, no number (the forecaster's own chance of this, stated with the estimate: 15%); middle value at least 5.0-fold (0.69 log units) away from the limit.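

In this assay compound 3 gives a limit of the assay and not a number: the limit of > 50000 nM in this assay, at which 1 of the 3 values shown sits. Shortening the chain produces a step beyond the scatter, an at least 5.9-fold higher number from compound 2 to compound 3 (0.77 log units; beyond the scatter), whereas the only earlier step, which exchanged the end group on the long chain, stayed within it. For the compounds shown here, the hydroxycarbamoyl end group on the shorter chain does not keep the number of the long-chain compound, and the comparison with the methylcarbamoyl chain points the same way, an at least 3.0-fold higher number from compound 1 to compound 3 (0.48 log units; beyond the scatter), so at this position the length of the chain moves the read-out, which the earlier compounds could not show.

From the compounds shown here alone, with a limit in place of a number, the full size of the step remains unknown, and one short chain cannot tell whether the number rises gradually or abruptly between the two lengths. Chains of intermediate length ending in hydroxycarbamoyl, a chain longer than that of compound 2, and a carboxylic acid or an amine as the end group would define how chain length and end group each contribute.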